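Carboxy for hydroxymethyl on a cyclohexene ring

This account rests on a few compounds, and the source may have more. Where it says the series, first, only, none or still open, it means among the compounds named here.

The series rests on two measured compounds. Compound 1, `C=C(C)[C@H]1CC[C@H](C)[C@H]2CCC(C(=O)O)=C[C@@H]21`, is tested in an assay on microsomes from liver for inhibition of Cocaine esterase (Homo sapiens), read by fluorescence, with a stated time of 10 min (on this read-out higher numbers stand for weaker inhibition and lower numbers for stronger inhibition), where compound 1 gives 1900 nM. Compound 2, `CC(C)(O)[C@@H]1CC=C(CO)CC1`, is a smaller molecule that carries a hydroxymethyl group on its ring; in this assay compound 2 gives 1900 nM. On these numbers compound 2 stands level with compound 1 at the digits shown, the two values lying within the scatter of each other.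

The step to compound 3, `CC(C)(O)[C@@H]1CC=C(C(=O)O)CC1`, keeps the core of compound 2 and makes one change: carboxy in place of hydroxymethyl on a double-bonded ring carbon. Within the data shown here, no step between two measured compounds mirrors this exchange, so the expectation for compound 3 rests on the two values above and on the change itself. Because compound 1, which carries a carboxy group, gives 1900 nM, the carboxy group in itself is expected to sit in the same region of potency. In this assay compound 3 is therefore expected to give 1900 nM, within a range from 600 nM to 6000 nM. The step is expected to be no change at the digits printed from compound 2 to compound 3 (within the scatter), that is, no change beyond the scatter.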

Compound 3, half-maximal inhibitory concentration: 1900 nM
Compound 3: middle estimate and measured number agree at the digits printed, and the stated range covers the measured number.
By their numbers in this assay, from the lowest: compounds 1, 2 and 3 (each within the scatter of the next).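

In this assay, among these compounds, the exchange of hydroxymethyl for carboxy on the double-bonded ring carbon gives no change at the digits printed from compound 2 to compound 3 (within the scatter) and so supplies the only step that can be read between compounds differing in one place. Compound 1 and compound 2 differ in more than one place, so their printed values said nothing about this position alone; the new step shows that, on the core of compound 2, this read-out does not separate the two groups at this ring carbon. Nothing measured here accounts for this result.

The compounds shown leave open whether a primary amide, a methyl ester or an amine on the same ring carbon would also stay within the scatter of compound 2 in this assay or would move clearly away from it. The part played by the 1-hydroxy-1-methylethyl group also remains open: the one step shown keeps that group in place, and reading it would take a compound with, for instance, a methyl group there instead.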